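This account rests on a few compounds, and the source may have more. Where it says the series, first, only, none or still open, it means among the compounds named here.

Working notes on the series in an ADME assay on HaCaT cells (Homo sapiens) for cytotoxicity, read by MTT assay, with a stated time of 72 h; a higher number here means a weaker inhibitor, a lower number a stronger inhibitor. Compound 2 `Cc1cc(S(=O)(=O)/N=C(\N)n2nccc2-c2ccccc2)c(SCc2cccc(Cl)c2)cc1Cl` gives 10000 nM. Compound 1 `Cc1cccc(CSc2cc(Cl)c(C)cc2S(=O)(=O)/N=C(\N)n2nccc2-c2ccccc2)c1` gives 10000 nM, and the step of no change at the digits printed from compound 1 to compound 2 (within the scatter) lies within the scatter, so the two stand level and together form the lowest pair of the three numbers. Compound 3 `Cc1cc(-c2ccccc2)n(/C(N)=N/S(=O)(=O)c2cc(C)c(Cl)cc2SCc2cccc(C(F)(F)F)c2)n1` gives 40000 nM; the gap between compound 2 and compound 3 is beyond the scatter, but compound 3 differs from compound 2 in more than one place, so only the two values themselves can be compared.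

The next step is from compound 2 to compound 4 `Cc1cc(S(=O)(=O)/N=C(\N)n2nccc2-c2ccccc2)c(SCc2ccccc2)cc1Cl`: hydrogen in place of chloro on an aromatic carbon, that is, 3-chlorobenzyl to benzyl on the benzylsulfanyl arm. Going by the values given here, the only single-point step on record in this assay, chloro in place of methyl on the same aromatic ring, is no change at the digits printed from compound 1 to compound 2 (within the scatter), no change within the scatter. That change and the present one both touch a single substituent on that ring, so a step of similar size, none beyond the scatter, is expected for no change at the digits printed from compound 2 to compound 4 (within the scatter). For compound 4 the expected value in this assay is 10000 nM, with a range from 5000 nM to 20000 nM, on the ground that compound 2 gives 10000 nM and the recorded step there was no change at the digits printed from compound 1 to compound 2 (within the scatter).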

Compound 4, half-maximal inhibitory concentration: 18000 nM
The estimate for compound 4 lay 1.8-fold (0.26 log units) below the measured number, and the stated range covers the measured number.
By their numbers in this assay, from the lowest: compounds 1, 2 and 4 (each within the scatter of the next); then compound 3.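

In this assay the series now has hydrogen on this aromatic carbon of the benzylsulfanyl arm, so the unsubstituted benzyl can be read against both substituted arms: 3-chlorobenzyl to benzyl gives a step within the scatter (a 1.8-fold higher number from compound 2 to compound 4 (0.26 log units; within the scatter)), and hydrogen in place of methyl also gives a step within the scatter (a 1.8-fold higher number from compound 1 to compound 4 (0.26 log units; within the scatter)). Taken with the step already on record (no change at the digits printed from compound 1 to compound 2 (within the scatter)), all three pairs among hydrogen, methyl and chloro at this place lie within the scatter, so none of these three groups separates compound 1, compound 2 and compound 4 here. No measured evidence bearing on this reading is at hand.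

Going by these compounds, whether a carboxylic acid, an amine or a methoxy group on the same aromatic carbon would also stand level with these three remains open. The trifluoromethyl of compound 3 gives no answer, since compound 3 differs from compound 1, compound 2 and compound 4 in more than one place, and its gap to them therefore cannot be assigned to that group.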